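Adding Two Methyls to a Sub-Nanomolar Sulfonamide

The source may hold more compounds than are shown below. What is called first, only, known or untested is meant among the compounds shown, and "the series" means these compounds.

Compound 1 (`O=C(/C=C/c1cccnc1)NCCCc1cccc(S(=O)(=O)Nc2ccccc2)c1`): 86.8 nM
Compound 2 (`O=C(/C=C/c1cccnc1)NCCCCCCc1cccc(S(=O)(=O)Nc2ccccc2)c1`): 0.88 nM

In a functional assay on K562 cells (Homo sapiens) for inhibition, read by CCK-8 assay, with a stated time of 72 h (on this read-out lower numbers stand for stronger inhibition and higher numbers for weaker inhibition), compound 2 holds the lower of the two numbers, and compound 1 lies above it by a gap well beyond the scatter of repeated measurements. Compound 2 is therefore the better of the pair and the reference for the next comparison.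

That comparison is with compound 3 (`Cc1ccc(C)c(NS(=O)(=O)c2cccc(CCCCCCNC(=O)/C=C/c3cccnc3)c2)c1`), which carries 2,5-dimethylphenyl in place of phenyl on a sulfonamide nitrogen. Everything else in compound 2 stays as it is. Within the data shown here, no measured pair changes this group, so the data offer no direct guide to the swap. The expectation therefore starts from compound 2 at 0.88 nM and keeps a wide margin around it. In this assay the estimated step is small and toward weaker inhibition (a 1.7-fold higher number from compound 2 to compound 3 (0.23 log units; within the scatter)) and is not expected to pass the scatter. For compound 3 the estimated value is 1.5 nM with an expected range of 0.3 nM to 8 nM on this read-out.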

Compound 3, half-maximal inhibitory concentration: 0.84 nM
Compound 3: middle estimate off by 1.8-fold (0.25 log units), on the high side; low and high end bracket the measured number.
By their numbers in this assay, from the lowest: compounds 3 and 2 (each within the scatter of the next); then compound 1.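

In this assay, putting 2,5-dimethylphenyl in place of phenyl on a sulfonamide nitrogen gives a 1.0-fold lower number from compound 2 to compound 3 (0.02 log units; within the scatter), so the two values cannot be told apart. Among these compounds, this is the first information on this position, since compound 1 and compound 2 both carry phenyl there and differ only in the chain, and it shows that the position accepts the methyl groups of 2,5-dimethylphenyl while the reading of compound 2 is kept in compound 3. Nothing in the available data explains why this change leaves the number within the scatter.

The compounds shown leave open whether either methyl group alone would read the same, and whether a chlorine, a methoxy group or a pyridine ring in place of phenyl on the sulfonamide nitrogen would be accepted as well. Also open, on these data alone, is whether 2,5-dimethylphenyl would behave the same way on the shorter chain of compound 1, whose number lies well above those of compound 2 and compound 3.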